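Nitro Enters the Fused Ring: Compound 3 to Compound 4

This account rests on a few compounds, and the source may have more. Where it says the series, first, only, none or still open, it means among the compounds named here.

Four compounds with a shared core were tested in a functional assay on PLC-PRF-5 cells (Homo sapiens) for inhibition; a higher number here means a weaker inhibitor, a lower number a stronger inhibitor. Compound 1, `CNC(=O)c1cc(Oc2ccc(NS(=O)(=O)c3ccc(C(C)(C)C)cc3)cc2)ccn1`, gives > 40000 nM, which is a limit of the assay and not a number. Compound 2, `O=[N+]([O-])c1cccc2c(Oc3ccc(NS(=O)(=O)c4ccc(C(F)(F)F)cc4Br)cc3)ccnc12`, likewise reaches only the limit > 40000 nM. Going by the values given here, compound 3, `O=C(Nc1ccc(Oc2ccnc3ccccc23)cc1)c1cc(C(F)(F)F)ccc1F`, is the one member with a real reading: in this assay compound 3 gives 21100 nM. Among the compounds with values here, the rest of the picture is the limit of > 40000 nM in this assay, at which 2 of the 3 values shown sit, so compound 3 stands as the only value that can be compared with anything.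

Compound 4, `O=C(Nc1ccc(Oc2ccnc3c([N+](=O)[O-])cccc23)cc1)c1cc(C(F)(F)F)ccc1F`, has not yet been measured. It differs from compound 3 in a single place: nitro in place of hydrogen on an aromatic carbon, that is, a nitro in place of hydrogen on an aromatic carbon. Within the data shown here, no pair of measured compounds differs in one place, so the size of such a step cannot be read from these data. Compound 2 also carries a nitro group, but it differs from the others in several further places, and its limit says little about the nitro alone. For compound 4 the step of a 1.2-fold higher number from compound 3 to compound 4 (0.07 log units; within the scatter) is expected to stay within the usual scatter, with no clear direction. Compound 4 is estimated at 25000 nM, with a likely range from 8000 nM to 80000 nM.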

Compound 4, half-maximal inhibitory concentration: > 40000 nM
Compound 4: a limit, no number; the forecaster's own chance of this, stated with the estimate: 35%; at least 1.6-fold (0.20 log units) between middle value and limit.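

Going by these compounds alone, the nitro on an aromatic carbon of the fused two-ring system gives the first comparison in this set between two compounds that differ in one place: in this assay the change is an at least 1.8-fold higher number from compound 3 to compound 4 (0.27 log units; that floor lies within the scatter). Compound 4 gives > 40000 nM, which is a limit of the assay and not a number, so the step has only a floor and the true size of the change cannot be read. The result shows that this nitro brings no gain in this assay, although the floor alone does not prove a real loss, and compound 3 remains the only member with a real reading: the limit of > 40000 nM in this assay, at which 3 of the 4 values shown sit.

The compounds shown leave open how far the true value of compound 4 lies past its limit, and so whether the nitro weakens inhibition by a little or by a lot. Within the data shown here, whether an amine or a methoxy group on this same aromatic carbon would give a real reading, and how that reading would compare with the one for compound 3, also stays open.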